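The source may report more compounds than this note shows. Statements on the series, on what has been measured and on what is new or still open speak of the compounds shown alone.

Compound 1 `COc1cc(OC)c(C(C)=O)c(OC)c1` is a small aromatic ketone carrying three methoxy groups. In a functional assay on MIA PaCa-2 cells (Homo sapiens) for cytotoxicity, read by resazurin assay, with a stated time of 72 h (on this read-out higher numbers stand for weaker inhibition and lower numbers for stronger inhibition), compound 1 gives 14300 nM, and this is the only numerical result in the set. Compound 2 `COc1cc(OC)c(C(=O)/C=C/c2ccccc2)c(OC)c1` extends the ketone into a conjugated chain ending in a second aromatic ring. For compound 2 this assay reports only a limit, > 20000 nM, and not a number (the limit of > 20000 nM in this assay, at which 1 of the 2 values shown sits). Within the data shown here, no two measured compounds differ in a single place, so no measured step is available to build on.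

Compound 3 `COCOc1cc(OC)cc(OC)c1C(C)=O` has not yet been tested. Compared with compound 1 it differs in one way: methoxy in place of hydrogen on a saturated chain carbon bound to an oxygen on an aromatic ring. The ketone, the core and the remaining methoxy groups stay as they are. Among the measured compounds shown here, with no comparable step among the measured compounds, the expectation rests on the smallness of the change. It is expected that this assay moves little, if at all, from compound 1 to compound 3, a step of about a 1.1-fold higher number from compound 1 to compound 3 (0.05 log units; within the scatter), which stays within the usual scatter. Compound 3 is therefore estimated at 16000 nM, with a plausible range from 6000 nM to 40000 nM.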

Compound 3, half-maximal inhibitory concentration: > 20000 nM
Compound 3 gave a limit, no number; the forecaster's own chance of this, stated with the estimate: 30%; middle value at least 1.2-fold (0.09 log units) away from the limit.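

Swapping the methoxy group of compound 1 for methoxymethoxy gives the first step in this set between two compounds that differ in one place, and in this assay that step is an at least 1.3-fold higher number from compound 1 to compound 3 (0.14 log units; that floor lies within the scatter). Even the smallest step this result allows stays within the scatter, so it does not show that the longer group truly weakens inhibition, only that it brings no measurable gain in strength at this position. Without a number for compound 3, the real size of the step cannot be read, and limits now make up most of the results shown: the limit of > 20000 nM in this assay, at which 2 of the 3 values shown sit.

As far as these compounds go, whether compound 3 truly differs from compound 1 stays open, as does the question of whether this one change says anything about other groups placed here. A hydroxyl group, an ethoxy group or a longer chain carrying an amine at this oxygen might behave quite differently, and a single step gives no basis for predicting any of them.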